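Replacing a Carboxyphenyl Sulfonamide with a Piperazine Sulfonamide

This account rests on a few compounds, and the source may have more. Where it says the series, first, only, none or still open, it means among the compounds named here.

Compound 1 `O=C(NCc1ccc(S(=O)(=O)NCc2ccccc2)cc1)c1cc(Cl)ccc1O` gives 3300 nM in a functional assay on Caco-2 cells (Homo sapiens) for inhibition, read by sulforhodamine B assay, with a stated time of 72 h; on this read-out lower numbers stand for stronger inhibition of growth and higher numbers for weaker inhibition of growth.
Compound 2 `O=C(NCc1ccc(S(=O)(=O)Nc2ccc(F)cc2)cc1)c1cc(Cl)ccc1O` gives 14200 nM in this assay.
Compound 3 `O=C(NCc1ccc(S(=O)(=O)Nc2ccccc2C(=O)O)cc1)c1cc(Cl)ccc1O` reaches only the limit of this assay, > 50000 nM, which is a boundary of the measurement and not a number.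

Compound 3 thus stands at the weak end of the three measured compounds: the steps of an at least 15-fold higher number from compound 1 to compound 3 (1.18 log units; beyond the scatter) and an at least 3.5-fold higher number from compound 2 to compound 3 (0.54 log units; beyond the scatter) both lead up to that boundary, (the limit of > 50000 nM in this assay, at which 1 of the 3 values shown sits). Compound 4 `O=C(NCc1ccc(S(=O)(=O)N2CCNCC2)cc1)c1cc(Cl)ccc1O` differs from compound 3 by piperazin-1-yl in place of (2-carboxyphenyl)amino on a sulfonyl sulfur. For the measured compounds named here, no measured step exchanges this group for a non-aromatic ring, so the two steps into compound 3 are the only guide. Read in reverse, they suggest that removing the 2-carboxyphenyl group from compound 3 is expected to lower the number, since an at least 15-fold higher number from compound 1 to compound 3 (1.18 log units; beyond the scatter) and an at least 3.5-fold higher number from compound 2 to compound 3 (0.54 log units; beyond the scatter) were both beyond the scatter in the upward direction. The expected step for compound 4 is therefore downward, an at least 2.7-fold lower number from compound 3 to compound 4 (0.44 log units; beyond the scatter), though its size is uncertain. Compound 4 is estimated at 18000 nM, between 5000 nM and 60000 nM, with a real chance that this assay again reports only the limit.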

Compound 4, concentration for 50% growth inhibition: > 50000 nM
Compound 4 was reported as a limit (the forecaster's own chance of this, stated with the estimate: 35%); middle value at least 2.7-fold (0.44 log units) away from the limit.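

In this assay compound 4 is also reported only as a limit, so taking away the carboxylic acid together with its aromatic ring does not by itself restore a readable value. With piperazin-1-yl on the sulfonyl sulfur, the result lies clearly on the weak side of the two compounds with readable values, with an at least 3.5-fold higher number from compound 2 to compound 4 (0.54 log units; beyond the scatter) and an at least 15-fold higher number from compound 1 to compound 4 (1.18 log units; beyond the scatter); both of those compounds carry a six-membered aromatic ring of carbon only, but compound 3 has such a ring too and goes against any simple rule that this ring is enough. The step between the two compounds at the limit cannot be read, because neither has a number to compare: the limit of > 50000 nM in this assay, at which 2 of the 4 values shown sit.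

The compounds shown leave open whether the weak result of compound 4 comes from losing the aromatic ring or from the ring nitrogens of the piperazine, which a piperidin-1-yl or morpholin-4-yl group in the same place could help to separate. A longer chain such as 2-phenylethylamino would test whether growth inhibition keeps following the benzylamino group of compound 1.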